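The compounds below may be only part of what the source reports. "The series", "measured", "known", "first", "only" and "open" are said of these compounds alone.

Compound 1 `Cc1cccc(CSc2cc(Cl)c(C)cc2S(=O)(=O)/N=C(\N)n2nccc2-c2ccccc2)c1` and compound 2 `Cc1cc(-c2ccccc2)n(/C(N)=N/S(=O)(=O)c2cc(C)c(Cl)cc2SCc2cccc(C(F)(F)F)c2)n1` are the two members of this series with a number in hand. In an ADME assay on microsomes from liver (Homo sapiens) for metabolic stability, read by LC-MS, using NADPH, tested at 5 uM (on this read-out higher numbers stand for a longer-lived compound and lower numbers for a shorter-lived compound), compound 1 gives 0.232 h, and in this assay compound 2 gives 0.169 h. Compound 1 has the higher of the two numbers, but the gap to compound 2 falls within the usual scatter of repeated measurements, so the two values cannot be told apart with confidence. Going by the values given here, no single-change step between measured compounds is available.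

Compound 3 `Cc1cc(S(=O)(=O)/N=C(\N)n2nccc2-c2ccccc2)c(SCc2ccccc2C(F)(F)F)cc1Cl` has not yet been measured in this assay. It differs from compound 1 as follows: 2-(trifluoromethyl)phenyl in place of 3-methylphenyl on a saturated chain carbon bound to a sulfur. Since both measured compounds sit close together, with compound 1 at 0.232 h and compound 2 at 0.169 h, the data give no basis for expecting a step beyond the scatter in either direction.

Compound 3 is therefore expected to give 0.2 h in this assay, somewhere between 0.1 h and 0.4 h. The expected step of a 1.2-fold lower number from compound 1 to compound 3 (0.06 log units; within the scatter) is estimated to be small and within the scatter.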

Compound 3, half-life: 0.15 h
The estimate for compound 3 lay 1.3-fold (0.12 log units) above the measured number; measured number inside the range.
By their numbers in this assay, from the lowest: compounds 3, 2 and 1 (each within the scatter of the next).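

Going by these compounds alone, the swap of 3-methylphenyl for 2-(trifluoromethyl)phenyl on a saturated chain carbon bound to a sulfur gives the first single-change step, and in this assay it reads as a 1.5-fold lower number from compound 1 to compound 3 (0.19 log units; within the scatter). The two half-lives therefore cannot be told apart, so at this place the entering group, with 10 heavy atoms against 7 for the one that leaves, gives no measurable separation from compound 1 on this read-out. Nothing measured here explains the result or ties it to any property of either group.

This single step changes the identity of the ring substituent and its ring position together, so it cannot say what each contributes alone, and a 2-methylphenyl group on the core of compound 1 would be needed to separate the two. It also leaves open whether any group at this place can give a step beyond the scatter, for instance a benzyl bearing a carboxylic acid or an amine, or a longer chain between the sulfur and the ring.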